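Swapping tert-Butyl for Benzyl on the Amide Nitrogen

A few compounds are considered here, and "the series" means these few. Any claim that something is new, unique, unknown or untested is made for them only; others in the source may bear on it.

Of the compounds shown here, three sharing one core have been tested in a functional assay on QGY7701 cells (Homo sapiens) for cytotoxicity, read by MTT assay, with a stated time of 24 h; a lower number here means a stronger inhibitor, a higher number a weaker inhibitor. Compound 1 `C=CC1=C(C(=O)Nc2ccccc2)C(c2ccc(Cl)c(Cl)c2)OC1` returned only a limit, > 100000 nM. Compound 2 `C=CC1=C(C(=O)NC(C)(C)C)C(c2ccc(OC)cc2)OC1` likewise returned only a limit, > 100000 nM. Compound 3 `C=CC1=C(C(=O)Nc2cccc(C)c2)C(c2ccc(F)cc2)OC1` gave a number, 56400 nM, weak as well. Compound 2 thus sits at the limit of > 100000 nM in this assay, at which 2 of the 3 values shown sit, so nothing finer than weak activity is known of it. Compound 4 `C=CC1=C(C(=O)NCc2ccccc2)C(c2ccc(OC)cc2)OC1` differs from compound 2 in one place (benzyl in place of tert-butyl on an amide-type nitrogen). Going by the values given here, no measured pair isolates this change, so its size cannot be read from the data. The expected step is a number no higher from compound 2 to compound 4 (the limit leaves the size open), nothing beyond the usual scatter. Compound 4 is therefore expected to show about 100000 nM in this assay, with a range from 40000 nM to 250000 nM.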

Compound 4, half-maximal inhibitory concentration: > 100000 nM
Compound 4: only a limit was reported; the forecaster's own chance of this, stated with the estimate: 60%; the middle value sits exactly at the limit.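

Compound 2 and compound 4 each returned only a limit, and the step between them cannot be read. The compounds shown leave open whether benzyl in place of tert-butyl on the amide-type nitrogen changes activity at all.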